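A few compounds are considered here, and "the series" means these few. Any claim that something is new, unique, unknown or untested is made for them only; others in the source may bear on it.

Working notes on the series. In a functional assay on HepG2 cells (Homo sapiens) for cytotoxicity, read by MTT assay, with a stated time of 72 h (on this read-out lower numbers stand for stronger inhibition and higher numbers for weaker inhibition), compound 1 `Nc1ccccc1NC(=O)c1ccc(NC(=S)NCc2cccnc2)cc1` gives 4200 nM and stands second highest of three numbers. Compound 2 `Nc1ccccc1NC(=O)c1ccc(NC(=O)/C(Cl)=C(\Cl)c2cccnc2)cc1` gives 560 nM and compound 3 `Nc1ccccc1NC(=O)c1ccc(NC(=O)NCc2ccc(F)nc2)cc1` gives 13000 nM in this assay and both gaps from compound 1 lie beyond the scatter. Among the measured compounds shown here, no two measured compounds differ in one place, so no measured step shows what a single change does here. Compound 4 `Cc1ccc(CNC(=S)Nc2ccc(C(=O)Nc3ccccc3N)cc2)cn1` carries methyl in place of hydrogen on an aromatic carbon as methyl in place of hydrogen on an aromatic carbon, next to the ring nitrogen. No step beyond the scatter is expected, and no direction is favoured. The estimated step of a 1.1-fold lower number from compound 1 to compound 4 (0.04 log units; within the scatter) is expected to remain within the scatter. For compound 4 the expected value is 3800 nM with an estimated span of 1500 nM to 9500 nM as its range.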

Compound 4, half-maximal inhibitory concentration: 11000 nM
For compound 4 the middle estimate is 2.9-fold (0.46 log units) below the measured one; the whole stated range lies below it.
By their numbers in this assay, from the lowest: compound 2; then compound 1; then compounds 4 and 3 (each within the scatter of the next).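

Among the compounds shown here, the change from pyridin-3-yl to 6-methylpyridin-3-yl gives a 2.6-fold higher number from compound 1 to compound 4 (0.42 log units; beyond the scatter) in this assay and so provides the first readable single change. This position, next to the ring nitrogen, is therefore not indifferent to added methyl, and the modest step runs towards weaker inhibition. Nothing shown explains the step.

Going by these compounds, whether an ethyl group, a methoxy group or an amine at this place would move the number in the same direction remains open. So does whether methyl here has the same effect with the linker of compound 2 or compound 3.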